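The compounds below may be only part of what the source reports. "The series", "measured", "known", "first", "only" and "open" are said of these compounds alone.

Compound 1 `Cc1cccc(-c2nc(SC[C@H]3C[C@@](C)(O)CC(=O)O3)[nH]c2-c2cccc(C)c2)c1.Cc1cccc(-c2nc(SC[C@H]3C[C@](C)(O)CC(=O)O3)[nH]c2-c2cccc(C)c2)c1`: 64 nM
Compound 2 `CC1=CC(=O)OC(CSc2nc(-c3ccccc3)c(-c3ccccc3)[nH]2)C1`: 200 nM

In an assay on microsomes from liver for inhibition of sterol O-acyltransferase 1 (Rattus norvegicus) (on this read-out higher numbers stand for weaker inhibition and lower numbers for stronger inhibition), compound 2 gives 200 nM, the highest of the two numbers; compound 1 gives 64 nM, a gap beyond the usual scatter. Compound 3 `CC1(C)CC(=O)OC(CSc2nc(-c3ccccc3)c(-c3ccccc3)[nH]2)C1` has not yet been measured. It differs from compound 2 by a group of 9 heavy atoms (7 carbon, 2 oxygen; one six-membered non-aromatic ring with 1 hetero atom) in place of a group of 8 heavy atoms (6 carbon, 2 oxygen; one six-membered non-aromatic ring with 1 hetero atom), on a saturated chain carbon bound to a sulfur. Within the data shown here, no measured pair shows this kind of change, so no step for it is known. The change is small in size and leaves the rest of the molecule untouched, so the expected step is a 1.3-fold higher number from compound 2 to compound 3 (0.10 log units; within the scatter), not beyond the scatter. Compound 3 is expected to give 250 nM, with a range from 100 nM to 650 nM.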

Compound 3, half-maximal inhibitory concentration: 100 nM
Estimate against measurement, compound 3: 2.5-fold (0.40 log units) above; the range from low to high includes it.
By their numbers in this assay, from the lowest: compounds 1, 3 and 2 (each within the scatter of the next, the first and the last beyond it).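

In this assay, among these compounds, the step of a 2.0-fold lower number from compound 2 to compound 3 (0.30 log units; within the scatter) is the first reading of a change at this place, on a saturated chain carbon bound to a sulfur. The group with 1 double bond outside aromatic rings and the group with 2 such bonds cannot be told apart here, so this swap, which also adds a carbon, leaves the number within the scatter. Nothing available explains this result. Still open, as far as these compounds go, is whether an amine or an ethyl group on this ring would keep the number in the same range.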